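From 4-Fluorophenyl to 2-Chloro-4-(trifluoromethyl)phenyl

The source may report more compounds than this note shows. Statements on the series, on what has been measured and on what is new or still open speak of the compounds shown alone.

Two compounds measured in a functional assay on A549 cells (Homo sapiens) for inhibition, read by MTT assay, with a stated time of 72 h (on this read-out higher numbers stand for weaker inhibition and lower numbers for stronger inhibition), set the scene. Compound 1 `COc1ccc(-n2cc(C(=O)Nc3ccc(Oc4ccnc5[nH]ccc45)cc3)c(=O)c3ccccc32)cc1` gives 4980 nM in this assay. Compound 2 `Cn1ccc2c(Oc3ccc(NC(=O)c4cn(-c5ccc(F)cc5)c5ccccc5c4=O)cc3F)ccnc21` gives 1460 nM in this assay, which is the lowest of the two numbers, with compound 1 standing a clear distance higher, beyond the scatter. For the measured compounds named here, the two compounds differ in several places, so no single step links them.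

Compound 3 `Cn1ccc2c(Oc3ccc(NC(=O)c4cn(-c5ccc(C(F)(F)F)cc5Cl)c5ccccc5c4=O)cc3F)ccnc21` has not yet been measured. It differs from compound 2 in one place, namely 2-chloro-4-(trifluoromethyl)phenyl in place of 4-fluorophenyl on an aromatic nitrogen and nothing else changes. Going by the values given here, no measured pair shows the effect of a change of this kind, so any expectation rests on compound 2 alone and on the size of the change. In this assay the expected step is a 1.5-fold lower number from compound 2 to compound 3 (0.16 log units; within the scatter), small and leaning toward a lower number, but not clearly beyond the scatter. Among the compounds with values here, compound 3 is therefore estimated at 1000 nM in this assay, with a range from 300 nM to 4000 nM that allows for the uncertainty of a change with no measured precedent here.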

Compound 3, half-maximal inhibitory concentration: 2050 nM
Beside the measured number, compound 3's estimate is 2.1-fold (0.31 log units) below it; the measured number falls inside the stated range.
By their numbers in this assay, from the lowest: compounds 2 and 3 (each within the scatter of the next); then compound 1.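

In this assay, for the compounds shown here, the first single-place change at this position gives a 1.4-fold higher number from compound 2 to compound 3 (0.15 log units; within the scatter), so the number does not move beyond the scatter. The aromatic nitrogen thus carries 2-chloro-4-(trifluoromethyl)phenyl, with 11 heavy atoms, as well as 4-fluorophenyl, with 7, and the read-out remains at the same level within this pair. This one pair says nothing about the chlorine or the trifluoromethyl group taken alone, as the two arrive together in a single step, and nothing shown bears on why the two numbers lie so close.

Going by these compounds, it remains open whether a different group on this nitrogen, such as a morpholine, a carboxylic acid or a longer alkyl chain in place of the six-membered aromatic ring of carbon, would move the number beyond the scatter. On these data alone, it is also open which of the several places that separate compound 1 from compound 2 accounts for the distance between their numbers, and whether 2-chloro-4-(trifluoromethyl)phenyl would behave the same way on the core of compound 1.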